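Working notes: from compound 2 to compound 4

This account rests on a few compounds, and the source may have more. Where it says the series, first, only, none or still open, it means among the compounds named here.

Measured in a functional assay on L1210 cells (Mus musculus) for inhibition; on this read-out higher numbers stand for weaker inhibition and lower numbers for stronger inhibition:
- compound 1 `CN(C)CCCNc1ncnc2c1C(=O)C(N1CCCCC1)=CC2=O`: 0.406 ug/mL
- compound 2 `COC(=O)CNc1ncnc2c1C(=O)C(OC)=CC2=O`: 1.2 ug/mL
- compound 3 `COC(=O)C(Nc1ncnc2c1C(=O)C(OC)=CC2=O)C(C)C`: 0.825 ug/mL

Compound 2, at 1.2 ug/mL, lies above compound 1 at 0.406 ug/mL and within the scatter of compound 3. Compound 4 `CCN(CC)CCCNc1ncnc2c1C(=O)C(OC)=CC2=O` follows from 2-(diethylamino)ethyl in place of methoxycarbonyl on a saturated chain carbon bound to a nitrogen on an aromatic ring. Going by the values given here, the only measured step, a 1.5-fold lower number from compound 2 to compound 3 (0.16 log units; within the scatter), changes the same chain carbon but brings a different group, so it offers little guidance. Compound 1, at 0.406 ug/mL, carries a comparable amino chain but differs elsewhere on the core, which makes it a loose guide. A modest lowering is therefore expected in this assay, possibly no larger than the scatter. The expected step is a 2.4-fold lower number from compound 2 to compound 4 (0.38 log units; beyond the scatter). Compound 4 is estimated at 0.5 ug/mL, with an expected range of 0.15 ug/mL to 1.6 ug/mL.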

Compound 4, half-maximal inhibitory concentration: 0.393 ug/mL
Compound 4: the middle estimate sits 1.3-fold (0.10 log units) above what was measured, within the range that was stated.
By their numbers in this assay, from the lowest: compounds 4 and 1 (each within the scatter of the next); then compounds 3 and 2 (each within the scatter of the next).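

In this assay the exchange of methoxycarbonyl for 2-(diethylamino)ethyl on a saturated chain carbon bound to a nitrogen on an aromatic ring gives a 3.1-fold lower number from compound 2 to compound 4 (0.48 log units; beyond the scatter) as a modest change. Going by these compounds alone, the earlier step at this chain carbon, a 1.5-fold lower number from compound 2 to compound 3 (0.16 log units; within the scatter), stayed within the scatter, so this is the first sign that the number responds to the group carried here. Nothing measured on these compounds accounts for the step.

The compounds shown do not separate the terminal diethylamine from the chain that carries it. A plain butyl chain, or a carboxylic acid at the chain end, would tell the two apart.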